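The source may report more compounds than this note shows. Statements on the series, on what has been measured and on what is new or still open speak of the compounds shown alone.

Measured in a functional assay on PC-3 cells (Homo sapiens) for inhibition, read by sulforhodamine B assay; on this read-out lower numbers stand for stronger inhibition of growth and higher numbers for weaker inhibition of growth:
- compound 1 `COc1cc(-c2ccc(-c3ccc(-c4nc5cc(C)ccc5[nH]4)cc3)cc2)cc(OC)c1OC`: 180 nM
- compound 2 `Fc1ccc(-c2ccc(-c3ccc(-c4nc5ccccc5[nH]4)cc3)cc2)cc1`: 41200 nM
- compound 3 `FC(F)(F)c1ccc(-c2ccc(-c3ccc(-c4nc5ccccc5[nH]4)cc3)cc2)cc1`: 45200 nM

Compound 3, at 45200 nM, sits level with compound 2 within the usual scatter, and both lie far above compound 1, at 180 nM. Compound 4 `Oc1ccc(-c2ccc(-c3ccc(-c4nc5ccccc5[nH]4)cc3)cc2)cc1` carries hydroxy in place of trifluoromethyl on an aromatic carbon, turning 4-(trifluoromethyl)phenyl into 4-hydroxyphenyl: hydroxy in place of trifluoromethyl on an aromatic carbon.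

Among the compounds with values here, only one measured step bears on this change: a 1.1-fold higher number from compound 2 to compound 3 (0.04 log units; within the scatter). Swapping one group for another there left the number within the scatter. Compound 1 differs from compound 3 in more than one place, so it gives no direct measure of this swap. Within the data shown here, no measured compound here carries hydroxy, which leaves the expectation loose. In this assay, among the measured compounds shown here, no step clearly beyond the scatter is expected, only a slight lean towards a lower number. The expected step is a 1.8-fold lower number from compound 3 to compound 4 (0.26 log units; within the scatter). For compound 4 the estimated value is 25000 nM, with an expected range of 6000 nM to 50000 nM.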

Compound 4, concentration for 50% growth inhibition: 47000 nM
The estimate for compound 4 lay 1.9-fold (0.27 log units) below the measured number; measured number inside the range.
By their numbers in this assay, from the lowest: compound 1; then compounds 2, 3 and 4 (each within the scatter of the next).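

In this assay, hydroxy in place of trifluoromethyl gives a 1.0-fold higher number from compound 3 to compound 4 (0.02 log units; within the scatter), and hydroxy in place of fluoro gives a 1.1-fold higher number from compound 2 to compound 4 (0.06 log units; within the scatter). Within the data shown here, until now this position had been seen only with fluoro and trifluoromethyl; hydroxy is a smaller group than trifluoromethyl and carries a hydrogen-bond donor and acceptor where trifluoromethyl carries neither, yet the number still stays within the scatter, so all three groups read alike here. Nothing available explains why these three groups read alike.

From the compounds shown here alone, whether an amine or a carboxylic acid at this position would move the number remains open. Compound 1 differs from compound 2, compound 3 and compound 4 in more than one place, so its much lower number cannot be traced to any single change.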